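Replacing the 4-methoxyphenyl group of compound 1

The source may report more compounds than this note shows. Statements on the series, on what has been measured and on what is new or still open speak of the compounds shown alone.

Measured in an ADME assay on HepG2 2.2.15 cells (Homo sapiens) for cytotoxicity, read by CCK-8 assay, with a stated time of 8 days; a higher number here means that more compound is tolerated, a lower number that less compound is tolerated:
Compound 1 `COc1ccc(-c2cc(NC(=O)c3ccc(Cl)cc3O)c[nH]c2=O)cc1`: 50500 nM
Compound 2 `COc1ccc(-c2cc(NC(=O)c3ccc(C)cc3O)c[nH]c2=O)cc1`: 46100 nM

Within the data shown here, only two numbers exist so far, and they stand level, so compound 1 sits within the scatter of the one other measured compound. The next compound, compound 3 `Cc1cccc(-c2cc(NC(=O)c3ccc(Cl)cc3O)c[nH]c2=O)c1`, keeps the chloro group and the core of compound 1 but carries 3-methylphenyl in place of 4-methoxyphenyl on an aromatic carbon. That carbon lies on a six-membered aromatic ring with 1 nitrogen, two atoms from the ring nitrogen.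

Among the measured compounds shown here, no measured step touches this place. For the measured compounds named here, the one step available, methyl in place of chloro at another place in the molecule, is small: a 1.1-fold lower number from compound 1 to compound 2 (0.04 log units; within the scatter). It sets no size for the exchange at hand, so the expectation rests on the level of the two measured values, and no step beyond the scatter is expected in this assay, though with wide uncertainty. The expected change is a 1.1-fold lower number from compound 1 to compound 3 (0.05 log units; within the scatter). For compound 3 the estimated value is 45000 nM, with an expected range from 20000 nM to 100000 nM.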

Compound 3, half-maximal cytotoxic concentration: 33100 nM
Estimate against measurement, compound 3: 1.4-fold (0.13 log units) above; the measured number falls inside the stated range.
By their numbers in this assay, from the lowest: compounds 3, 2 and 1 (each within the scatter of the next).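

In this assay, among these compounds, this aromatic carbon, two atoms from the ring nitrogen, has now been changed for the first time, and exchanging 4-methoxyphenyl for 3-methylphenyl gives a 1.5-fold lower number from compound 1 to compound 3 (0.18 log units; within the scatter). The earlier pair showed only that methyl and chloro at another place stand level, whereas this step shows that the aryl group here can differ in two ways at once without leaving the scatter: the entering group has no hydrogen-bond acceptor where the leaving group has one, and its single substituent sits at another place on the ring. No measurement shown offers an explanation for this result.

Because both features change in one exchange, the step cannot say what either contributes alone, and 3-methoxyphenyl or 4-methylphenyl at this carbon would be needed to separate them. On these data alone, it also remains open whether a more different group here, such as an aminophenyl or carboxyphenyl ring or a longer alkyl chain in place of the aryl ring, would shift the number in this assay beyond the scatter.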